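Dichlorophenyl anilino change in an acrylamide quinazoline-type series

The source may hold more compounds than are shown below. What is called first, only, known or untested is meant among the compounds shown, and "the series" means these compounds.

Of the compounds shown here, three have been measured in a functional assay on NCI-H1975 cells (Homo sapiens) for inhibition, read by MTT assay, with a stated time of 72 h; a higher number here means a weaker inhibitor, a lower number a stronger inhibitor. For the measured compounds named here, compound 1 `O=C(CSc1nc(Nc2ccccc2)c2ccccc2n1)Nc1ccccc1F` gives 9350 nM and compound 2 `CCc1ccc(NC(=O)CSc2nc(Nc3ccccc3)c3ccccc3n2)cc1` gives 9910 nM; the only single-site step among them, a 1.1-fold higher number from compound 1 to compound 2 (0.03 log units; within the scatter), concerns the amide-type nitrogen and shows that a change there left the number essentially where it was. Compound 3 `C=CC(=O)Nc1cccc(NC(=O)CSc2nc(Nc3cccc(F)c3)c3ccccc3n2)c1` gives 2030 nM, the lowest of the three numbers, beyond the scatter from both compound 1 and compound 2; it differs from each of them in more than one place, so no single step explains its position.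

Compound 4 `C=CC(=O)Nc1cccc(NC(=O)CSc2nc(Nc3ccc(Cl)cc3Cl)c3ccccc3n2)c1` differs from compound 3 by 2,4-dichlorophenyl in place of 3-fluorophenyl on a nitrogen on an aromatic ring. Going by the values given here, no measured step touches this nitrogen, and the one step that exists, at the other nitrogen, was within the scatter. The expectation is therefore cautious: the number for compound 4 is estimated to stay near that of compound 3, with a step of a 1.2-fold higher number from compound 3 to compound 4 (0.09 log units; within the scatter) allowed in either direction but not expected to reach beyond the scatter with confidence. On that basis compound 4 is estimated at 2500 nM in this assay, within a range from 800 nM to 8000 nM.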

Compound 4, half-maximal inhibitory concentration: 5990 nM
Compound 4: the middle estimate sits 2.4-fold (0.38 log units) below what was measured; low and high end bracket the measured number.
By their numbers in this assay, from the lowest: compound 3; then compounds 4, 1 and 2 (each within the scatter of the next).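

In this assay, the nitrogen on an aromatic ring proves to be a position where a change of group can move the number: replacing 3-fluorophenyl with 2,4-dichlorophenyl gives a 3.0-fold higher number from compound 3 to compound 4 (0.47 log units; beyond the scatter) and so yields a weaker inhibitor, although the step is modest. The only earlier single-site step, a 1.1-fold higher number from compound 1 to compound 2 (0.03 log units; within the scatter) at the amide-type nitrogen, showed no such movement, so this is the first change in the series shown that lies beyond the scatter. No measurement available here accounts for the step, which therefore stands as an observation without an established cause.

Fluorine leaves and two chlorine atoms enter in this single change, so the compounds shown cannot separate the loss of the 3-fluorophenyl group from the contribution of either chlorine. Going by these compounds, it also remains open how the number in this assay would respond to a phenyl group at this nitrogen carrying a single chlorine, a methoxy group or a dimethylamino group, and whether any such group would give a stronger inhibitor than compound 3.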